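The source may hold more compounds than are shown below. What is called first, only, known or untested is meant among the compounds shown, and "the series" means these compounds.

Working notes on the series, read in an in vitro ADME assay on microsomes from liver (Rattus norvegicus) for metabolic stability; on this read-out lower numbers stand for slow clearance and higher numbers for fast clearance:

- compound 1 `CC(C)NC(=O)[C@H]1CC[C@@H](n2/c(=N/C(=O)c3ccc(F)cc3)[nH]c3ccc(CN4CC(C(C)(C)O)C4)cc32)CC1`: < 14 mL.min-1.g-1
- compound 2 `CC(C)NC(=O)[C@H]1CC[C@@H](n2/c(=N/C(=O)c3cccc(C#N)c3)[nH]c3ccc(CN4CCC(C(C)(C)O)CC4)cc32)CC1`: 17 mL.min-1.g-1
- compound 3 `CCN(CC)C(=O)[C@H]1CC[C@@H](n2/c(=N/C(=O)c3ccccc3)[nH]c3ccc(CN4CCCCC4)cc32)CC1`: 682 mL.min-1.g-1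

Compound 1 gives < 14 mL.min-1.g-1, which is a limit of the assay and not a number. Compound 2 gives 17 mL.min-1.g-1, the lowest of the two numbers in hand. The nearest number belongs to compound 3, which gives 682 mL.min-1.g-1, a gap well beyond the scatter.

The next compound to read is compound 4 `CC(C)NC(=O)[C@H]1CC[C@@H](n2/c(=N/C(=O)c3ccccc3)[nH]c3ccc(CN4CCC(C(C)(C)O)CC4)cc32)CC1`. Relative to compound 2 it carries hydrogen in place of cyano on an aromatic carbon, meta to a large group: hydrogen in place of cyano on an aromatic carbon.

Among the measured compounds shown here, no measured pair shows this change alone, so the expectation rests on compound 2 at 17 mL.min-1.g-1. In this assay the expected step is a 1.2-fold higher number from compound 2 to compound 4 (0.07 log units; within the scatter), a slight rise that is expected to stay within the scatter. For compound 4 the estimated value is 20 mL.min-1.g-1, with an expected range of 10 mL.min-1.g-1 to 45 mL.min-1.g-1.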

Compound 4, intrinsic clearance in microsomes: 21 mL.min-1.g-1
The estimate for compound 4 lay 1.1-fold (0.02 log units) below the measured number, and the stated range covers the measured number.
By their numbers in this assay, from the lowest: compounds 2 and 4 (each within the scatter of the next); then compound 3. At a limit, below all of these: compound 1.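

In this assay, among the compounds shown here, replacing 3-cyanophenyl with phenyl gives a 1.2-fold higher number from compound 2 to compound 4 (0.09 log units; within the scatter), the first step that isolates a single place. With the rest of the structure kept, the nitrile on this aromatic carbon is therefore not required for a low number in this read-out. Compound 1 stands at a limit of the assay and not at a number, and the values of this pair are read not far from that floor: the limit of < 14 mL.min-1.g-1 in this assay, at which 1 of the 4 values shown sits.

From the compounds shown here alone, what a methoxy group or a carboxylic acid on this aromatic carbon would do stays open, as does whether the same replacement reads alike in a compound with a much higher number, such as compound 3. For the compounds shown here, no single-place step connects compound 3 to the others, so its gap cannot be assigned to any one part of the structure.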